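The source may hold more compounds than are shown below. What is called first, only, known or untested is meant among the compounds shown, and "the series" means these compounds.

Measured in an ADME assay, at pH 3 (a lower number here means that the compound disappears faster, a higher number that the compound lasts longer), so far
- compound 1 `COc1cnc(C[S+]([O-])c2nc3cc(OC(F)F)ccc3[nH]2)c(C)c1OC` gives 0.2 h
- compound 2 `COc1ccnc(C[S+]([O-])c2nc3cc(OC(F)F)ccc3[nH]2)c1` gives 0.117 h
- compound 3 `COc1ccnc(C[S+]([O-])c2nc3cc(OC(F)F)ccc3[nH]2)c1C` gives 0.0833 h

Compound 3 stands at the low end of the three, within the scatter of compound 2 and clearly short of compound 1 only. Compound 4 `COc1ccnc(C[S+]([O-])c2nc3cc(OC(F)(F)C(F)F)ccc3[nH]2)c1C` replaces difluoromethoxy with 1,1,2,2-tetrafluoroethoxy, and the change reads difluoromethyl in place of hydrogen on a saturated chain carbon bound to two fluorine atoms and an oxygen on an aromatic ring in full. Neither measured step touches this group, so neither is a direct precedent. They show only the size of changes elsewhere: a 1.4-fold lower number from compound 2 to compound 3 (0.15 log units; within the scatter) stays within the scatter, and a 2.4-fold lower number from compound 1 to compound 3 (0.38 log units; beyond the scatter) is modest. From the compounds shown here alone, no clear shift is therefore expected in this assay and the direction stays open. The estimated step is a 1.1-fold higher number from compound 3 to compound 4 (0.03 log units; within the scatter) and should not exceed the scatter. For compound 4 the expected value is 0.09 h with an estimated range of 0.05 h to 0.17 h at this stage.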

Compound 4, half-life: 0.0833 h
The estimate for compound 4 lay 1.1-fold (0.03 log units) above the measured number, within the range that was stated.
By their numbers in this assay, from the lowest: compounds 3, 4, 2 and 1 (each within the scatter of the next, the first and the last beyond it).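

In this assay, within the data shown here, the step from difluoromethoxy to 1,1,2,2-tetrafluoroethoxy gives no change at the digits printed from compound 3 to compound 4 (within the scatter), the first reading at this position. On the core of compound 3, the added difluoromethyl leaves the half-life where it was, so this position tolerates that extension without a visible shift in this assay. Nothing available explains this result.

From the compounds shown here alone, whether the same change behaves alike with the other substituents of compound 1 or compound 2 remains open. So does the effect of an amine or a longer perfluoroalkyl chain in place of the difluoromethoxy.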